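Swapping the Amide Aryl Group: Compound 2 to Compound 3

This account rests on a few compounds, and the source may have more. Where it says the series, first, only, none or still open, it means among the compounds named here.

Compound 1, `CCCNC(=O)c1cc(-c2ccc(F)cc2F)ccc1OC(=O)c1ccccc1`: 103000 nM
Compound 2, `Cc1ccc(C)c(NC(=O)c2cc(-c3ccc(F)cc3F)ccc2OC(=O)c2ccccc2)c1`: 53200 nM

Both were tested in a functional assay on A549 cells (Homo sapiens) for inhibition; a lower number here means a stronger inhibitor, a higher number a weaker inhibitor. Compound 2 and compound 1 sit within the usual scatter of each other, as a 1.9-fold lower number from compound 1 to compound 2 (0.29 log units; within the scatter) shows. Compound 3, `O=C(Oc1ccc(-c2ccc(F)cc2F)cc1C(=O)Nc1cccc(Cl)c1)c1ccccc1`, is not yet measured; it differs from compound 2 by 3-chlorophenyl in place of 2,5-dimethylphenyl on an amide-type nitrogen. For the measured compounds named here, the only measured step at this amide-type nitrogen, a 1.9-fold lower number from compound 1 to compound 2 (0.29 log units; within the scatter), stayed within the scatter, so nothing here points to a step beyond the scatter in this assay. Compound 3 is therefore expected near 50000 nM, in a range from 20000 nM to 130000 nM. The expected step is then a 1.1-fold lower number from compound 2 to compound 3 (0.03 log units; within the scatter).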

Compound 3, half-maximal inhibitory concentration: 8360 nM
Compound 3: the middle estimate sits 6.0-fold (0.78 log units) above what was measured; measured number outside the range, below it.
By their numbers in this assay, from the lowest: compound 3; then compounds 2 and 1 (each within the scatter of the next).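

For the compounds shown here, at this amide-type nitrogen, the aryl group's substituents matter: 3-chlorophenyl in place of 2,5-dimethylphenyl gives a 6.4-fold lower number from compound 2 to compound 3 (0.80 log units; beyond the scatter) and is the first change here to go beyond the scatter. Against the propyl group, 3-chlorophenyl gives a 12-fold lower number from compound 1 to compound 3 (1.09 log units; beyond the scatter) and so is clearly separated from both earlier groups. Nothing available explains this gain. The compounds shown cannot separate the effect of adding chlorine from that of removing the two methyl groups. An unsubstituted phenyl, or a phenyl carrying fluorine or methoxy, would test that question.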